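Dropping One Chloro from the Dichlorophenyl Ketone

This account rests on a few compounds, and the source may have more. Where it says the series, first, only, none or still open, it means among the compounds named here.

Measured compounds:
compound 1 `O=C(/C=C/c1ccc(/C=C/C(=O)c2cc(Cl)ccc2Cl)o1)NO` — 48300 nM
compound 2 `O=C(/C=C/c1ccc(/C=C/C(=O)c2ccc3ccccc3c2)o1)NO` — 9930 nM
compound 3 `CC(C)c1ccc(C(=O)/C=C/c2ccc(/C=C/C(=O)NO)o2)cc1` — 35900 nM

Three analogues sharing one core have been tested in a functional assay on HepG2 cells (Homo sapiens) for antiproliferative activity, read by MTT assay, with a stated time of 48 h; a higher number here means a weaker inhibitor, a lower number a stronger inhibitor. Compound 1 gives 48300 nM, the highest number of the three. Compound 3 gives 35900 nM, which sits within the scatter of compound 1. Compound 2 gives 9930 nM, a number beyond the scatter and clearly lower than that of compound 1.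

The next compound, compound 4 `O=C(/C=C/c1ccc(/C=C/C(=O)c2cccc(Cl)c2)o1)NO`, differs from compound 1 in a single place: hydrogen in place of chloro on an aromatic carbon. The change sits on the ring of the ketone, at the carbon ortho to a large group and para to the remaining chloro group.

For the measured compounds named here, no step of this kind exists among the measured compounds, so the direction is open. Going by the values given here, the data show only that compound 3, carrying a different ring substitution, lands near compound 1. Compound 4 is therefore expected to stay close to compound 1, with a 1.3-fold lower number from compound 1 to compound 4 (0.10 log units; within the scatter) estimated as no step beyond the scatter. Compound 4 is estimated at 38000 nM, within a range of 13000 nM to 95000 nM.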

Compound 4, half-maximal inhibitory concentration: 54500 nM
Beside the measured number, compound 4's estimate is 1.4-fold (0.16 log units) below it; measured number inside the range.
By their numbers in this assay, from the lowest: compound 2; then compounds 3, 1 and 4 (each within the scatter of the next).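

In this assay, for the compounds shown here, replacing the chloro group on this aromatic carbon, ortho to a large group and para to the remaining chloro group, with hydrogen gives a 1.1-fold higher number from compound 1 to compound 4 (0.05 log units; within the scatter) and is the first single-place step in this set. At this position, the two compounds cannot be told apart, so the chloro group here is not needed to keep the number where compound 1 has it. No measurement on hand bears on the reason for this match.

Going by these compounds, it remains open whether a different group on this same carbon, such as a methoxy group, an amine or a carboxylic acid, would also leave the number within the scatter. Also open, on these data alone, is what would happen if the remaining chloro group gave way to hydrogen.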